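The source may report more compounds than this note shows. Statements on the series, on what has been measured and on what is new or still open speak of the compounds shown alone.

Series notes. Going by the values given here, the shared core carries a secondary amine on an aromatic ring, and the three measured members differ only in what sits on that nitrogen. Compound 1 `CCCCCCCCC(C)Nc1ccc(NC(=O)c2cc(Cl)ccc2O)c(Cl)c1` carries the longest chain; in an ADME assay on A549 cells (Homo sapiens) for cytotoxicity, read by resazurin assay, with a stated time of 48 h (a lower number here means that less compound is tolerated, a higher number that more compound is tolerated), compound 1 gives 21900 nM. Compound 2 `O=C(Nc1ccc(NCC2CC2)cc1Cl)c1cc(Cl)ccc1O` gives 14400 nM in this assay, and compound 3 `CC1(Nc2ccc(NC(=O)c3cc(Cl)ccc3O)c(Cl)c2)CCCC1` gives 157000 nM. Compound 1 thus stands second highest of the three numbers: its gap to compound 2 lies within the scatter, while compound 3 sits clearly higher, beyond the scatter. Among the compounds with values here, the one step between neighbours that differ in a single place is an 11-fold higher number from compound 2 to compound 3 (1.04 log units; beyond the scatter).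

Compound 4 `CC(CCO)Nc1ccc(NC(=O)c2cc(Cl)ccc2O)c(Cl)c1` is not yet measured. It differs from compound 1 in one place: hydroxy in place of hexyl on a saturated chain carbon, three bonds along the chain from a nitrogen on an aromatic ring. Within the data shown here, no measured pair mirrors this change; the step from compound 2 to compound 3 concerns a different replacement on the same nitrogen and is the only guide to how far a change at that position can move the number. That compound 1 and compound 2, with chains of very different length, sit within the scatter of each other argues against a large shift. A modest rise is expected for compound 4, a 1.8-fold higher number from compound 1 to compound 4 (0.26 log units; within the scatter). The estimate for compound 4 is 40000 nM, with the expected range running from 12000 nM to 130000 nM.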

Compound 4, half-maximal cytotoxic concentration: 200000 nM
The estimate for compound 4 lay 5.0-fold (0.70 log units) below the measured number, outside the stated range (above it).
By their numbers in this assay, from the lowest: compounds 2 and 1 (each within the scatter of the next); then compounds 3 and 4 (each within the scatter of the next).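

In this assay, the replacement of hexyl by hydroxy on a saturated chain carbon, three bonds along the chain from a nitrogen on an aromatic ring, gives a 9.1-fold higher number from compound 1 to compound 4 (0.96 log units; beyond the scatter), so this part of the chain can move the number well beyond the scatter, although the earlier comparison of compound 1 with compound 2 had shown no such spread. Until now, only the 1-methylcyclopentyl group had stood at the high end of the series, yet the open-chain 3-hydroxy-1-methylpropyl group reaches the same level, with a 1.3-fold higher number from compound 3 to compound 4 (0.11 log units; within the scatter) remaining within the scatter. The other comparison, a 14-fold higher number from compound 2 to compound 4 (1.14 log units; beyond the scatter), confirms this, and at this nitrogen a ring in the substituent is therefore not needed for a high number (compound 4) and does not ensure one (compound 2).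

As far as these compounds go, the change from compound 1 to compound 4 removes the hexyl group and adds the hydroxy group in a single step, so the separate share of each stays open; an unsubstituted butyl group, or an amine or a carboxylic acid in place of the hydroxy, would bear on that question. No measured evidence accounts for these steps.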